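Bromo to Methyl on the Aryl Ring of Compound 1

The source may hold more compounds than are shown below. What is called first, only, known or untested is meant among the compounds shown, and "the series" means these compounds.

Measured compounds in an assay on isolated protein for inhibition of Amine oxidase [flavin-containing] B (Homo sapiens); a lower number here means a stronger inhibitor, a higher number a weaker inhibitor:
- compound 1, `O=C(/C=C/c1ccc(Br)cc1)c1ccc(-n2ccnc2)cc1`, gives 320 nM in this assay
- compound 2, `CCOc1ccc(C(=O)/C=C/c2ccc(Br)cc2)cc1`, gives 210 nM in this assay
- compound 3, `COc1ccc(C(=O)/C=C/c2ccc(O/N=C(\C)c3ccccc3)cc2)cc1`, reaches only the limit > 200 nM in this assay, which is a limit of the assay and not a number

Among the numbers shown, compound 1 and compound 2 sit within the scatter of each other, the step of a 1.5-fold lower number from compound 1 to compound 2 (0.18 log units; within the scatter) being the only measured step in the set; the third value shown is a limit (the limit of > 200 nM in this assay, at which 1 of the 3 values shown sits).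

The compound not yet measured is compound 4, `Cc1ccc(/C=C/C(=O)c2ccc(-n3ccnc3)cc2)cc1`. It differs from compound 1 by methyl in place of bromo on an aromatic carbon, a change on the other ring from that altered between compound 1 and compound 2. No measured step therefore bears directly on this change, and the only step shown, a 1.5-fold lower number from compound 1 to compound 2 (0.18 log units; within the scatter), was itself within the scatter. On this basis compound 4 is expected to stay close to compound 1, with the step of a 1.3-fold higher number from compound 1 to compound 4 (0.10 log units; within the scatter) estimated to lie within the scatter in either direction. Compound 4 is estimated at 400 nM in this assay, within a range from 150 nM to 1200 nM.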

Compound 4, half-maximal inhibitory concentration: 320 nM
The estimate for compound 4 lay 1.3-fold (0.10 log units) above the measured number; the range from low to high includes it.
By their numbers in this assay, from the lowest: compounds 2, 1 and 4 (each within the scatter of the next).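

Among the compounds shown here, the only earlier measured step altered the other ring, whereas this pair changes the 4-bromophenyl group itself: methyl in place of bromo gives no change at the digits printed from compound 1 to compound 4 (within the scatter) in this assay. Bromine is therefore not required at this position for inhibition of this size, at least with the 1H-imidazol-1-yl group held constant, and a carbon substituent serves in its place. Nothing in the data shown accounts for the two groups reading alike.

Whether the position accepts groups of a different kind remains open, as no value is shown for an amine, a carboxylic acid or a longer chain such as butyl in place of bromo. On these data alone, it is also open whether methyl and bromo would read alike on the ethoxy-bearing core of compound 2.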